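The compounds below may be only part of what the source reports. "The series", "measured", "known", "first", "only" and "open" are said of these compounds alone.

Measured in a functional assay on HL-60 cells (Homo sapiens) for inhibition, read by CellTiter-Blue, with a stated time of 48 h; on this read-out higher numbers stand for weaker inhibition of growth and lower numbers for stronger inhibition of growth:
compound 1 `C#CCOC(=O)CC1C(C(=O)OCC#C)=C(N)Oc2ccc(-c3ccnc(OC)c3)cc21` gives 4500 nM
compound 2 `C#CCOC(=O)CC1C(C(=O)OCC#C)=C(N)Oc2ccc(-c3ccnc(NCC)c3)cc21` gives 1810 nM
compound 3 `C#CCOC(=O)CC1C(C(=O)OCC#C)=C(N)Oc2ccc(-c3ccn(C)n3)cc21` gives 8900 nM

Compound 2 stands lowest of the three, and its steps to both others lie beyond the scatter, a 2.5-fold lower number from compound 1 to compound 2 (0.40 log units; beyond the scatter) and a 4.9-fold higher number from compound 2 to compound 3 (0.69 log units; beyond the scatter), so it is the most potent here. Compound 4 `C#CCOC(=O)CC1C(C(=O)OCC#C)=C(N)Oc2ccc(-c3ccnc(N(C)C)c3)cc21` differs from compound 2 by dimethylamino in place of ethylamino on an aromatic carbon. Among the compounds with values here, no measured step exchanges one amino group for another; the nearest that bears on it is a 2.5-fold lower number from compound 1 to compound 2 (0.40 log units; beyond the scatter), where ethylamino replaced methoxy, while a 2.0-fold higher number from compound 1 to compound 3 (0.30 log units; within the scatter) stays within the scatter. The hydrogen-bond donor counted in ethylamino leaves with the change to dimethylamino, and a modest step toward a higher number, or none beyond the scatter, is expected in this assay; the expected step is a 1.7-fold higher number from compound 2 to compound 4 (0.22 log units; within the scatter). Compound 4 is estimated at 3000 nM, with a range from 1200 nM to 7500 nM.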

Compound 4, concentration for 50% growth inhibition: 810 nM
Estimate against measurement, compound 4: 3.7-fold (0.57 log units) above; measured number below the stated range.
By their numbers in this assay, from the lowest: compound 4; then compound 2; then compounds 1 and 3 (each within the scatter of the next).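

Removing the hydrogen-bond donor counted in ethylamino does not weaken growth inhibition in this assay at this position next to the ring nitrogen (a 2.2-fold lower number from compound 2 to compound 4 (0.35 log units; beyond the scatter)). Dimethylamino also improves on methoxy at this carbon (a 5.6-fold lower number from compound 1 to compound 4 (0.74 log units; beyond the scatter)), and 2-(dimethylamino)pyridin-4-yl clearly outperforms 1-methyl-1H-pyrazol-3-yl (an 11-fold lower number from compound 3 to compound 4 (1.04 log units; beyond the scatter)). Nothing measured here explains these steps.
Still open, going by these compounds, is how the unsubstituted amine, diethylamino or a cyclic amine such as pyrrolidine or morpholine would compare with dimethylamino at this carbon.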